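The source may report more compounds than this note shows. Statements on the series, on what has been measured and on what is new or still open speak of the compounds shown alone.

In a functional assay on liver (Rattus norvegicus, strain Sprague-Dawley) for inhibition, with a stated time of 1 h (a lower number here means a stronger inhibitor, a higher number a weaker inhibitor), three compounds have numbers so far:

Compound 1 `COc1cc(C2Oc3cc([C@H]4Oc5cc(O)cc(O)c5C(=O)[C@@H]4O)ccc3OC2COC(=O)c2ccc(N)cc2)ccc1O` gives 14300 nM
Compound 2 `COc1cc(C2Oc3cc([C@H]4Oc5cc(O)cc(O)c5C(=O)[C@@H]4O)ccc3OC2COC(=O)c2ccc([N+](=O)[O-])cc2)ccc1O` gives 12600 nM
Compound 3 `COc1cc(C2Oc3cc([C@H]4Oc5cc(O)cc(O)c5C(=O)[C@@H]4O)ccc3OC2COC(=O)c2cc([N+](=O)[O-])cc([N+](=O)[O-])c2)ccc1O` gives 14600 nM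

All three values lie within the scatter of each other, so compound 3 at 14600 nM stands level with the other two. The next structure is compound 4 `COc1cc(C2Oc3cc([C@H]4Oc5cc(O)cc(O)c5C(=O)[C@@H]4O)ccc3OC2COC(=O)/C=C/c2ccc(C)cc2)ccc1O`, which has not yet been measured. It carries 2-(4-methylphenyl)ethenyl in place of 3,5-dinitrophenyl on a carbonyl carbon, and the counted difference is 2-(4-methylphenyl)ethenyl in place of 3,5-dinitrophenyl on a carbonyl carbon in that one place.

Earlier changes at this carbonyl carbon are the closest guide. They gave a 1.0-fold higher number from compound 1 to compound 3 (0.01 log units; within the scatter) and a 1.2-fold higher number from compound 2 to compound 3 (0.06 log units; within the scatter) as well as a 1.1-fold lower number from compound 1 to compound 2 (0.05 log units; within the scatter) and none of these left the scatter. For the measured compounds named here, no measured compound carries 2-(4-methylphenyl)ethenyl, so this guide is limited and the range stays wide. In this assay the expected result is a 1.1-fold lower number from compound 3 to compound 4 (0.05 log units; within the scatter) and no step beyond the scatter is expected. For compound 4 the estimate is 13000 nM with 6000 nM to 27000 nM as its expected range.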

Compound 4, half-maximal inhibitory concentration: 14700 nM
Estimate against measurement, compound 4: 1.1-fold (0.05 log units) below; the measured number falls inside the stated range.
By their numbers in this assay, from the lowest: compounds 2, 1, 3 and 4 (each within the scatter of the next).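

In this assay the group on the carbonyl carbon can now be made of carbon only, with no amino or nitro group and with an ethenyl link to its ring, and the number still stays level with the earlier ones (a 1.0-fold higher number from compound 3 to compound 4 (0.00 log units; within the scatter); a 1.2-fold higher number from compound 2 to compound 4 (0.07 log units; within the scatter); a 1.0-fold higher number from compound 1 to compound 4 (0.01 log units; within the scatter)). Losing both nitro groups of 3,5-dinitrophenyl, and with them all of that group's hydrogen-bond acceptors, therefore leaves the result within the scatter, so this position has now tolerated four different groups without a measurable change. Nothing at hand explains why these numbers stay level.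

Groups without an aromatic ring, such as a plain alkyl chain, an aliphatic amine or a carboxylic acid, remain open at this carbonyl carbon. On these data alone, whether any group here can move the number beyond the scatter also remains open.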